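The source may hold more compounds than are shown below. What is called first, only, known or untested is meant among the compounds shown, and "the series" means these compounds.

Of the compounds shown here, two have so far been measured in a physicochemical assay for lipophilicity, measured as octanol-water partition, at pH 7.4; on this read-out lower numbers stand for lower lipophilicity and higher numbers for higher lipophilicity. Compound 1 `CC(C)c1noc(N2CCC(Oc3cc(N4CCc5cc(N6CC(O)CCC6=O)ccc54)ncn3)CC2)n1` gives 2.6, and compound 2 `CC(C)OC(=O)N1CCC(Oc2cc(N3CCc4cc(S(C)(=O)=O)ccc43)ncn2)CC1` gives 3.1. Compound 1 is therefore the lower of the two, and the gap between them lies beyond the usual scatter of repeated measurements. The two differ in more than one place, so this gap cannot be tied to any single structural change.

The next compound to be measured is compound 3 `CC(C)c1noc(N2CCC(Oc3cc(N4CCc5cc(N6CCC(O)CC6=O)ccc54)ncn3)CC2)n1`, which has the same atoms as compound 1, joined differently. The change, on an aromatic carbon of a six-membered aromatic ring of carbon only, is 4-hydroxy-2-oxopiperidin-1-yl in place of 5-hydroxy-2-oxopiperidin-1-yl on an aromatic carbon. Going by the values given here, no measured pair shows the effect of such a change on this assay. The counted features are the same on both sides, so compound 3 is expected to stay close to compound 1 at 2.6, with no shift beyond the scatter. The expected step, no change at the digits printed from compound 1 to compound 3 (within the scatter), is only an estimate. For compound 3 the estimated value is 2.6, expected to fall between 2.3 and 2.9.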

Compound 3, distribution coefficient: 2.8
Compound 3: middle estimate off by 0.20 log units, on the low side; the measured number falls inside the stated range.
By their numbers in this assay, from the lowest: compounds 1, 3 and 2 (each within the scatter of the next, the first and the last beyond it).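

This first matched pair isolates one structural change: 4-hydroxy-2-oxopiperidin-1-yl in place of 5-hydroxy-2-oxopiperidin-1-yl on the aromatic carbon, with the rest of the molecule unchanged. In this assay, the result is a number 0.20 log units higher from compound 1 to compound 3 (within the scatter), so at this position, moving the hydroxy group from one ring carbon to the other within the oxopiperidinyl group does not separate the two isomers on this read-out. Going by these compounds alone, the pair therefore gives the first direct reading for this position, which the gap between compound 1 and compound 2 could not provide, but no explanation for the small difference between the isomers can be drawn from the information available.

The compounds shown leave open how much this assay responds when the hydroxy group itself is replaced, for example by an amine, a carboxylic acid or a methoxy group, rather than moved within the ring. Within the data shown here, they also leave open whether the same isomeric change would remain within the scatter on a different core or with another group in place of the isopropyl-bearing ring of compound 1, as only this single pair bears on the question.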